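Swapping chloro for methoxy on a benzyl group at the assay ceiling

The compounds below may be only part of what the source reports. "The series", "measured", "known", "first", "only" and "open" are said of these compounds alone.

The measured compounds and their values:
Compound 1 `COc1ccc2c(c1)c(/C=N\NC(=O)c1c[nH]c3ccc(Br)cc13)cn2Cc1ccc(Cl)cc1` in a functional assay on LNCaP cells (Homo sapiens) for cytotoxicity (a lower number here means a stronger inhibitor, a higher number a weaker inhibitor), gives a limit, > 100000 nM.
Compound 2 `O=C(N/N=C\c1cn(Cc2ccc(Cl)cc2)c2cc(F)ccc12)c1c[nH]c2ccccc12` in this assay gives 55200 nM.
Compound 3 `Cn1cc(C(=O)N/N=C\c2cn(Cc3ccc(Cl)cc3)c3cc(F)ccc23)c2ccccc21` in this assay gives a limit, > 100000 nM.

Compound 3 thus stands at the ceiling of this assay, as described by the limit of > 100000 nM in this assay, at which 2 of the 3 values shown sit, so only a limit and not a number is known for it. Going by the values given here, the single measured step, an at least 1.8-fold higher number from compound 2 to compound 3 (0.25 log units; that floor lies within the scatter), runs onto that limit and already lies within the scatter at its floor.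

Compound 4 `COc1ccc(Cn2cc(/C=N\NC(=O)c3cn(C)c4ccccc34)c3ccc(F)cc32)cc1` differs from compound 3 in one place: methoxy in place of chloro on an aromatic carbon. No measured step changes chloro to methoxy, so nothing shown bears directly on this change; the only step available concerns a methyl on an aromatic nitrogen instead. Starting from a limit, the step is expected to be a number no higher from compound 3 to compound 4 (the limit leaves the size open), that is, no change beyond the scatter. Compound 4 is therefore estimated at 100000 nM, within 30000 nM to 300000 nM, most likely reported again as a limit.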

Compound 4, half-maximal inhibitory concentration: 9600 nM
Compound 4: the middle estimate sits 10-fold (1.02 log units) above what was measured; measured number outside the range, below it.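

In this assay, the benzyl group proves to be a place where a single substituent can bring a compound off the ceiling: the change from 4-chlorobenzyl to 4-methoxybenzyl gives an at least 10-fold lower number from compound 3 to compound 4 (1.01 log units; beyond the scatter). Going by these compounds alone, compounds 1, 2 and 3 all carry 4-chlorobenzyl, so they could say nothing about this group, and this is the first sign that the read-out responds to it. The step gives only a floor and not a size, because the value of compound 3 is a limit: the limit of > 100000 nM in this assay, at which 2 of the 4 values shown sit.

The compounds shown leave open whether the methoxy change holds with hydrogen instead of methyl on the aromatic nitrogen, as in compound 2. They also leave open how a hydroxy, an amine or an ethoxy group would fare in the same place.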